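The compounds below may be only part of what the source reports. "The series", "measured", "known", "first", "only" and "open" are said of these compounds alone.

Among the measured compounds shown here, compound 2 `C#Cc1cccc(Nc2ncnc3cc(OC)c(OCCCn4ccnc4[N+](=O)[O-])cc23)c1` is one of two compounds measured in a functional assay on HT-29 cells (Homo sapiens) for cytotoxicity, read by sulforhodamine B assay, with a stated time of 72 h; a lower number here means a stronger inhibitor, a higher number a weaker inhibitor. In this assay compound 2 gives 5550 nM, the higher of the two numbers; the other compound, compound 1 `COc1cc2ncnc(Nc3cccc(Br)c3)c2cc1OCCCn1ccnc1[N+](=O)[O-]`, gives 4480 nM in this assay. For the measured compounds named here, the one step among the measured compounds, a 1.2-fold higher number from compound 1 to compound 2 (0.09 log units; within the scatter), leaves the two within the scatter of each other.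

Compound 3 `C#Cc1cccc(Nc2ncnc3cc(OC)c(OCCCCCCn4ccnc4[N+](=O)[O-])cc23)c1` is not yet measured in this assay. It differs from compound 2 in the chain alone: 3-(2-nitro-1H-imidazol-1-yl)propyl in place of 2-nitro-1H-imidazol-1-yl on a saturated chain carbon, three bonds along the chain from an oxygen on an aromatic ring. Going by the values given here, no measured step concerns this chain; the single step, from compound 1 to compound 2, changes a group on the other end of the molecule and was within the scatter. Among the compounds with values here, with no step that bears on the chain, nothing suggests a change in this assay beyond the scatter, so a step of a 1.0-fold lower number from compound 2 to compound 3 (0.00 log units; within the scatter) is expected, given with a wide range. Compound 3 is therefore estimated at 5500 nM, between 2000 nM and 15000 nM, in this assay.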

Compound 3, half-maximal inhibitory concentration: 2930 nM
Compound 3: the middle estimate sits 1.9-fold (0.27 log units) above what was measured; the measured number falls inside the stated range.
By their numbers in this assay, from the lowest: compounds 3, 1 and 2 (each within the scatter of the next).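

In this assay, the chain carrying the nitroimidazole now has a measured step of its own: 3-(2-nitro-1H-imidazol-1-yl)propyl in place of 2-nitro-1H-imidazol-1-yl, three bonds along the chain from an oxygen on an aromatic ring, gives a 1.9-fold lower number from compound 2 to compound 3 (0.28 log units; within the scatter). The earlier step concerned only the other end of the molecule, so this pair is the only one to show that the longer chain of compound 3 stays within the scatter of the shorter chain of compound 2 in this cell assay. No independent measurement is available to account for this result.

From the compounds shown here alone, whether a still longer chain, or an amine in place of the 2-nitro-1H-imidazol-1-yl group, would move the number beyond the scatter remains open. The compounds shown also leave open whether bromo in place of ethynyl would give the same result on the chain of compound 3.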